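Replacing the sulfonamide with a pyrazole on the fused core

This account rests on a few compounds, and the source may have more. Where it says the series, first, only, none or still open, it means among the compounds named here.

Compound 1, `Cn1nccc1-c1cccc2c1CCC2c1ncc[nH]1`: 58%
Compound 2, `c1cc(-c2nccs2)c2c(c1)C(c1ncc[nH]1)CC2`: 64%
Compound 3, `CCS(=O)(=O)Nc1cccc2c1CCC2c1ncc[nH]1`: 86%

These three compounds were measured in a functional assay on CHO cells for agonist activity at Alpha-1A adrenergic receptor (Homo sapiens), read by FLIPR and calcium flux; on this read-out higher numbers stand for larger maximal responses and lower numbers for smaller maximal responses. Compound 3 stands highest of the three numbers: compound 2 lies nearest to it, a number 22 percentage points higher from compound 2 to compound 3 (beyond the scatter), and compound 1 lies furthest, a number 28 percentage points higher from compound 1 to compound 3 (beyond the scatter). The two lower compounds differ only slightly, a number 6 percentage points higher from compound 1 to compound 2 (within the scatter).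

Compound 4, `c1cc(-c2cn[nH]c2)c2c(c1)C(c1ncc[nH]1)CC2`, has not yet been measured. It differs from compound 3 in one place: 1H-pyrazol-4-yl in place of (ethylsulfonyl)amino on an aromatic carbon. Among the measured compounds shown here, two measured steps bear on this change, since both introduced the group that now leaves: a number 28 percentage points higher from compound 1 to compound 3 (beyond the scatter) and a number 22 percentage points higher from compound 2 to compound 3 (beyond the scatter), each a modest rise in favour of the (ethylsulfonyl)amino group over a five-membered aromatic heterocycle on that carbon. Going back to a five-membered aromatic heterocycle is therefore expected to give a modest fall. Compound 4 is estimated at 62%, with a range of 45% to 80%, which would mean a number 24 percentage points lower from compound 3 to compound 4 (beyond the scatter) in this assay.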

Compound 4, largest response reached (Emax), in percent of the reference or control that the assay uses: 84%
For compound 4 the middle estimate is 22 percentage points below the measured one; the measured number lies above the stated range.
By their numbers in this assay, from the lowest: compounds 1 and 2 (each within the scatter of the next); then compounds 4 and 3 (each within the scatter of the next).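

In this assay, among the compounds shown here, the exchange of (ethylsulfonyl)amino for 1H-pyrazol-4-yl on this aromatic carbon gives a number 2 percentage points lower from compound 3 to compound 4 (within the scatter), so the sulfonamide group is not the only group at this position that reaches such a response, and compound 4 goes against the earlier pattern of lower numbers for five-membered aromatic rings. The identity of the ring now matters, with a number 20 percentage points higher from compound 2 to compound 4 (beyond the scatter) for 1H-pyrazol-4-yl in place of 1,3-thiazol-2-yl, and a number 26 percentage points higher from compound 1 to compound 4 (beyond the scatter) for 1H-pyrazol-4-yl in place of 1-methyl-1H-pyrazol-5-yl. Nothing available explains this difference among the rings.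

The compounds shown leave open whether the step from 1-methyl-1H-pyrazol-5-yl goes with the methyl group or with the ring's point of attachment, which 1-methyl-1H-pyrazol-4-yl would separate. They also leave open how an amine or a carboxylic acid would read on this carbon.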